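The compounds below may be only part of what the source reports. "The series", "measured", "known", "first", "only" and "open" are said of these compounds alone.

Compound 2 `c1ccc(-c2cn3ccnc3c(-c3ccc4ncn(C5CCCCC5)c4c3)n2)cc1` carries the higher of the two numbers recorded in a functional assay on SK-MEL-2 cells (Homo sapiens) for inhibition, read by sulforhodamine B assay, with a stated time of 48 h, tested at 10 uM; on this read-out higher numbers stand for more inhibition at the one concentration tested (going by the name of the read-out) and lower numbers for less inhibition; in this assay compound 2 gives 16.5%. Going by the values given here, its only neighbour is compound 1 `Brc1cn2ccnc2c(-c2ccc3ncn(C4CCCCC4)c3c2)n1`, which in this assay gives 10.2%, and the gap between the two lies within the scatter. Among the compounds with values here, the single measured step, a number 6.3 percentage points higher from compound 1 to compound 2 (within the scatter), put phenyl in place of bromo on an aromatic carbon and did not move the read-out beyond the scatter.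

Compound 3 `COc1ccc(-c2cn3ccnc3c(-c3ccc4ncn(C5CCCCC5)c4c3)n2)cc1` differs from compound 2 by methoxy in place of hydrogen on an aromatic carbon. Within the data shown here, no measured step touches this position. Among the measured compounds shown here, the one step known, a number 6.3 percentage points higher from compound 1 to compound 2 (within the scatter), concerns a different site and was itself small, so it offers no sign that this core responds strongly to substitution on the outer ring. The expected step is therefore a number 3.5 percentage points higher from compound 2 to compound 3 (within the scatter), with no direction beyond the scatter. Compound 3 is estimated to give 20% in this assay, within a range from 8% to 34%.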

Compound 3, a percentage reported as inhibition, at one concentration (the size of the read-out at that concentration, not a potency): 94.3%
Beside the measured number, compound 3's estimate is 74.3 percentage points below it, outside the stated range (above it).
By their numbers in this assay, from the lowest: compounds 1 and 2 (each within the scatter of the next); then compound 3.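

In this assay, the outer ring proves to be a sensitive place: methoxy in place of hydrogen on an aromatic carbon, para to a large group, gives a number 77.8 percentage points higher from compound 2 to compound 3 (beyond the scatter). The earlier exchange of bromo for phenyl had stayed within the scatter, whereas 4-methoxyphenyl in place of bromo gives a number 84.1 percentage points higher from compound 1 to compound 3 (beyond the scatter), so among these compounds the large rise appears only when the methoxy is present on the added ring. Nothing available here explains why so small an addition comes with so large a step.

As far as these compounds go, whether this rise is particular to methoxy remains open, as does whether it would also appear with another group at the same place, such as hydroxy, an amine, or a longer chain like ethoxy, or with methoxy placed elsewhere on the ring. The read-out also rests on a single concentration, so these numbers cannot tell how far the potency of compound 3 differs from that of compound 2.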